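Removing the Methoxy Group from Compound 2

The source may report more compounds than this note shows. Statements on the series, on what has been measured and on what is new or still open speak of the compounds shown alone.

Compound 1 `CCOC(=O)c1cc([Se]c2ccccc2)c2cc(Br)ccc2n1`: 20800 nM
Compound 2 `CCOC(=O)c1cc([Se]c2ccccc2)c2cc(OC)ccc2n1`: 102000 nM

Both compounds were tested in a functional assay on Jurkat cells (Homo sapiens) for cytotoxicity, read by MTT assay, with a stated time of 24 h; a higher number here means that more compound is needed for the effect, a lower number that less compound is needed. Among the compounds with values here, compound 2 holds the higher of the two numbers, and compound 1, its only measured neighbour, lies beyond the scatter from it. The next compound to be measured is compound 3 `CCOC(=O)c1cc([Se]c2ccccc2)c2ccccc2n1`, which has hydrogen in place of methoxy on an aromatic carbon.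

Within the data shown here, only one measured step bears on this change. It is the modest 4.9-fold higher number from compound 1 to compound 2 (0.69 log units; beyond the scatter), in which methoxy takes the place of bromo on an aromatic carbon. Among the measured compounds shown here, no measured compound yet carries hydrogen at this place, so that step offers only a rough guide. Taking away the methoxy group is expected to give a modest move towards a lower number in this assay, probably smaller than the measured step, and no change beyond the scatter remains possible. The expected change is a 2.3-fold lower number from compound 2 to compound 3 (0.36 log units; beyond the scatter). For compound 3 the estimated value is 45000 nM, with an expected range from 15000 nM to 110000 nM.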

Compound 3, half-maximal effective concentration: 98200 nM
Compound 3: middle estimate off by 2.2-fold (0.34 log units), on the low side; the measured number falls inside the stated range.
By their numbers in this assay, from the lowest: compound 1; then compounds 3 and 2 (each within the scatter of the next).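

In this assay the change shows a 1.0-fold lower number from compound 2 to compound 3 (0.02 log units; within the scatter) and so, on this aromatic carbon, meta to a fused ring and para to a fused ring, the methoxy group and hydrogen cannot be told apart. The earlier step from bromo to methoxy could be read as a mark of the methoxy group, but the new compound shifts that reading towards bromo, since a 4.7-fold higher number from compound 1 to compound 3 (0.67 log units; beyond the scatter) stands alongside a 4.9-fold higher number from compound 1 to compound 2 (0.69 log units; beyond the scatter) and both lie beyond the scatter. Among these three compounds, then, only the one carrying bromo stands apart in this assay and the other two share one level within the scatter.

Going by these compounds, whether a chloro or fluoro group, an amine or a carboxylic acid on this same carbon would fall with bromo or with hydrogen and methoxy remains open, so a single halogen cannot yet be turned into a rule for the position. Nothing available gives a reason why bromo differs from the other two groups here.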